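Swapping methoxy for trifluoromethoxy in a histamine agonist

A few compounds are considered here, and "the series" means these few. Any claim that something is new, unique, unknown or untested is made for them only; others in the source may bear on it.

Measured so far:
- compound 1, `COc1ccc(C(C)NC(=O)/N=C(\N)NCCCc2sc(N)nc2C)cc1`: 0.91
- compound 2, `Cc1nc(N)sc1CCCN/C(N)=N/C(=O)N[C@@H](C)c1ccccc1`: 1.08

Of the compounds shown here, two have been tested in a functional assay on Right cardiac atrium for agonist activity at histamine H2 receptor (Cavia porcellus), with a stated time of 30 min, in the presence of a further agent that is not named here; a higher number here means a larger maximal response, a lower number a smaller maximal response. Compound 1 gives 0.91 in this assay, and compound 2 gives 1.08. Of these two numbers, compound 1 stands lowest; its nearest neighbour is compound 2, whose value lies higher by more than the usual scatter of repeated measurements. Both compounds reach a maximal response close to that of the reference agonist.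

Compound 3, `Cc1nc(N)sc1CCCN/C(N)=N/C(=O)NC(C)c1ccc(OC(F)(F)F)cc1`, has not yet been measured. It differs from compound 1 in one place: trifluoromethyl in place of methyl on an oxygen on an aromatic ring. Among the compounds with values here, no pair of measured compounds shows this change, so no measured step is available to lean on.

Since compound 1 already produces a maximal response near the reference in this assay, and the change touches only the group on the oxygen on an aromatic ring, the expectation is a step from compound 1 to compound 3 of a number 0.010 higher from compound 1 to compound 3 (within the scatter), that is, no change beyond the scatter. Compound 3 is therefore estimated at 0.92, within a range from 0.78 to 1.06.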

Compound 3, intrinsic activity: the largest response reached, as a fraction of the reference agonist's: 0.61
Estimate against measurement, compound 3: 0.31 above; the measured number lies below the stated range.
By their numbers in this assay, from the lowest: compound 3; then compound 1; then compound 2.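

In this assay, the group on the oxygen on an aromatic ring proves not to be a neutral place in this series: going from methoxy to trifluoromethoxy gives a number 0.30 lower from compound 1 to compound 3 (beyond the scatter), so a change confined to this one group is enough to alter the maximal response while the rest of the molecule stays the same. The earlier compounds shown here could not show this, since compound 1 and compound 2 differ in more than one place and no measured step touched this oxygen. Nothing available here gives a reason for the drop.

From the compounds shown here alone, this is a single step, so it remains open whether the response falls gradually or abruptly as the group on this oxygen changes, and a hydrogen, an ethyl or a difluoromethyl in the same place would help to separate those possibilities. The read-out also captures only the largest response reached, which leaves open how the same change affects the concentration needed to reach it.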